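A few compounds are considered here, and "the series" means these few. Any claim that something is new, unique, unknown or untested is made for them only; others in the source may bear on it.

Compound 1 `COc1ccc(C2=Nn3c(nnc3C(C)c3ccc(-c4ccccc4)c(F)c3)SC2)cc1`: 4400 nM
Compound 2 `CC(C)Cc1ccc(C(C)c2nnc3n2N=C(c2ccc(Br)cc2)CS3)cc1`: 7100 nM

In a functional assay on HCT-116 cells (Homo sapiens) for inhibition, read by sulforhodamine B assay, with a stated time of 72 h (on this read-out higher numbers stand for weaker inhibition and lower numbers for stronger inhibition), compound 2 gives 7100 nM and compound 1 gives 4400 nM, so these two values lie within the usual scatter of each other. Compound 3 `CC(C)Cc1ccc(C(C)c2nnc3n2N=C(c2ccc(OC(F)(F)F)cc2)CS3)cc1` has trifluoromethoxy in place of bromo on an aromatic carbon of compound 2, para to a large group: trifluoromethoxy in place of bromo on an aromatic carbon. Among the compounds with values here, no measured pair shows a change at this place, so no shift beyond the scatter is expected in this assay. The estimated step is a 1.2-fold lower number from compound 2 to compound 3 (0.07 log units; within the scatter). Compound 3 is expected at 6000 nM, with an estimated range of 2500 nM to 15000 nM.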

Compound 3, half-maximal inhibitory concentration: 3000 nM
Compound 3: the middle estimate sits 2.0-fold (0.30 log units) above what was measured, within the range that was stated.
By their numbers in this assay, from the lowest: compounds 3, 1 and 2 (each within the scatter of the next, the first and the last beyond it).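

In this assay, trifluoromethoxy in place of bromo on an aromatic carbon, para to a large group, gives a 2.4-fold lower number from compound 2 to compound 3 (0.37 log units; beyond the scatter). Within the data shown here, this is the first step seen at this position, and although modest, it shows that the group placed here can change the read-out. Nothing available explains why this change has this effect.

The compounds shown leave open how an amine or a carboxylic acid would behave at this position. They also leave open whether the same change would give a similar step on a compound that differs elsewhere.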